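Cytotoxicity notes: amide cap changes on the shared core

A few compounds are considered here, and "the series" means these few. Any claim that something is new, unique, unknown or untested is made for them only; others in the source may bear on it.

Compound 1 `O=C(c1ccc(Cl)cc1)N1CCN(c2nc(=O)c3cc(C(F)(F)F)cc([N+](=O)[O-])c3s2)CC1`: in an ADME assay on Vero cells (Chlorocebus sabaeus) for cytotoxicity, read by MTT assay, with a stated time of 72 h (on this read-out higher numbers stand for lower toxicity in this test and lower numbers for higher toxicity in this test), compound 1 gives > 125000 nM, which is a limit of the assay and not a number.
Compound 2 `Cc1ccc(C(=O)N2CCN(c3nc(=O)c4cc(C(F)(F)F)cc([N+](=O)[O-])c4s3)CC2)cc1`: in this assay compound 2 gives > 125000 nM, likewise a limit.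

Among the compounds with values here, both measured compounds sit at the upper limit of this assay, so the step that the two limits leave unreadable from compound 1 to compound 2 cannot be read; the only evidence is the limit of > 125000 nM in this assay, at which 2 of the 2 values shown sit. Compound 2 therefore stands at the limit, with no number of its own on the series.

Compound 3 `O=C(C1CCCCC1)N1CCN(c2nc(=O)c3cc(C(F)(F)F)cc([N+](=O)[O-])c3s2)CC1` is the next change: cyclohexyl in place of 4-methylphenyl on a carbonyl carbon. Within the data shown here, no measured step bears on a cyclohexyl cap, and the one step in hand is unreadable. The shared core carried no measurable toxicity in either compound.

Compound 3 is expected to sit at 125000 nM, with a range from 60000 nM to 250000 nM. The expected step of a number no higher from compound 2 to compound 3 (the limit leaves the size open) is estimated as none beyond the scatter, most likely another limit.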

Compound 3, half-maximal cytotoxic concentration: 88700 nM
Compound 3: middle estimate off by 1.4-fold (0.15 log units), on the high side; the measured number falls inside the stated range.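

Of the compounds shown, only compound 3, with cyclohexyl on the carbonyl carbon, gives a number in this assay rather than a limit, so a cap with a non-aromatic ring can be read at this position. Cyclohexyl in place of 4-methylphenyl gives an at least 1.4-fold lower number from compound 2 to compound 3 (0.14 log units; that floor lies within the scatter), and cyclohexyl in place of 4-chlorophenyl gives an at least 1.4-fold lower number from compound 1 to compound 3 (0.14 log units; that floor lies within the scatter). Each step is known only as a floor because compound 1 and compound 2 are limits and not numbers: the limit of > 125000 nM in this assay, at which 2 of the 3 values shown sit.

The true size of both steps stays open, so a real difference between the aromatic caps and cyclohexyl is neither shown nor excluded. Also open, going by these compounds, is how this assay reads a cap carrying an amine or a carboxylic acid, or an open carbon chain such as hexyl, on the same carbonyl carbon.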